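A few compounds are considered here, and "the series" means these few. Any claim that something is new, unique, unknown or untested is made for them only; others in the source may bear on it.

Measured so far in an assay on HEK293 cells for activation of Kir3.1/Kir3.2 (Homo sapiens), read by fluorescence and thallium flux, with a stated time of 4 min; on this read-out higher numbers stand for an effect only at larger amounts of compound and lower numbers for an effect already at smaller amounts:
compound 1 `Cc1ccc(NC(=O)Nc2ccccc2)cc1S(=O)(=O)N(C)C`: 1400 nM
compound 2 `Cc1ccc(NC(=O)Nc2ccccc2Cl)cc1S(=O)(=O)N(C)C`: 2700 nM

Compound 1 gives the lowest of the two numbers in this assay; its nearest neighbour is compound 2, a 1.9-fold higher number from compound 1 to compound 2 (0.29 log units; within the scatter), so the two do not separate from each other.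

Compound 3 `Cc1ccc(NC(=O)Nc2ccc(C(F)(F)F)cc2)cc1S(=O)(=O)N(C)C` is not yet measured. It differs from compound 1 by trifluoromethyl in place of hydrogen on an aromatic carbon. Among the measured compounds shown here, the only measured step that bears on it is the one in which a substituent entered the same six-membered aromatic ring of carbon only, a 1.9-fold higher number from compound 1 to compound 2 (0.29 log units; within the scatter), which stayed within the scatter. For the measured compounds named here, no measured compound carries a trifluoromethyl group, so nothing speaks for a larger effect of this change in either direction. In this assay the step expected is a 1.1-fold higher number from compound 1 to compound 3 (0.03 log units; within the scatter), none beyond the scatter. Compound 3 is estimated at 1500 nM. For compound 3 the expected range runs from 500 nM to 4500 nM.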

Compound 3, half-maximal effective concentration: 1500 nM
Estimate against measurement, compound 3: no gap at the digits printed; measured number inside the range.
By their numbers in this assay, from the lowest: compounds 1, 3 and 2 (each within the scatter of the next).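

In this assay, trifluoromethyl in place of hydrogen on an aromatic carbon, para to a large group, gives a 1.1-fold higher number from compound 1 to compound 3 (0.03 log units; within the scatter), so this position accepts a group of 4 heavy atoms with no step beyond the scatter. Until now the only substituent tested on this six-membered aromatic ring of carbon only was the chloro of compound 2, and compound 3 shows that a second, different group also leaves the number within the scatter of compound 1. No measured evidence bears on this result.

On these data alone, whether an amine, a carboxylic acid or a longer chain at this place would give a step beyond the scatter remains open. With no such step among the compounds shown, it is also open which parts of the shared core the number depends on.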